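This account rests on a few compounds, and the source may have more. Where it says the series, first, only, none or still open, it means among the compounds named here.

Compound 2 `C=CCn1c(=O)n([C@H]2CO[C@@H](CO)C2)c2nc(N)nc(O)c21` is the lower of the two numbers in hand: in a functional assay on the whole organism (B cells) with Mus musculus as the target (on this read-out higher numbers stand for larger maximal responses and lower numbers for smaller maximal responses), compound 2 gives 10%, whereas compound 1 `C=CCn1c(=O)n(C2CCC(CO)C2)c2nc(N)nc(O)c21` gives 26%. Compound 3 `C=CCn1c(=O)n(CCCC)c2nc(N)nc(O)c21` differs from compound 2 by a group of 4 heavy atoms (4 carbon; no ring) in place of a group of 7 heavy atoms (5 carbon, 2 oxygen; one five-membered non-aromatic ring with 1 hetero atom), on an aromatic nitrogen. Among the compounds with values here, no measured step covers this change; the only step available, a number 16 percentage points lower from compound 1 to compound 2 (beyond the scatter), shows that exchanging the group on this aromatic nitrogen moves this assay by a modest amount, downward when a carbon-only ring becomes an oxygen-bearing one. For compound 3 a step back upward of about a number 12 percentage points higher from compound 2 to compound 3 (beyond the scatter) is expected. The estimate for compound 3 is 22%, in the range 5% to 42%.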

Compound 3, largest response reached (reported as maximal response), in percent of the reference or control that the assay uses: 77%
Estimate against measurement, compound 3: 55 percentage points below, and the stated range ends below it.
By their numbers in this assay, from the lowest: compound 2; then compound 1; then compound 3.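

In this assay the group on this aromatic nitrogen carries far more weight than the ring exchange alone suggested: butyl in place of the oxygen-bearing ring gives a large rise (a number 67 percentage points higher from compound 2 to compound 3 (beyond the scatter)), and butyl in place of the carbon-only ring gives another (a number 51 percentage points higher from compound 1 to compound 3 (beyond the scatter)). Among these three compounds, the open chain without a ring, hydrogen-bond donor or acceptor reads highest, and both ring-bearing groups read well under it. No measurement here offers an explanation for this rise. The compounds shown leave open whether the ring or the hydroxyl group matters more, and how hexyl or a butyl chain ending in an amine would read.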